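Triazole Substituent Swap on an Inactive Kinase Scaffold

The source may report more compounds than this note shows. Statements on the series, on what has been measured and on what is new or still open speak of the compounds shown alone.

Compound 1, `CNc1ncc2c(-c3ccc(N4CCNCC4)nc3)nn(CC3OCCO3)c2n1`, in an assay for inhibition of tyrosine-protein kinase receptor TYRO3 (Homo sapiens), read by 33P incorporation, in the presence of a further agent that is not named here; on this read-out lower numbers stand for stronger inhibition and higher numbers for weaker inhibition: > 10000 nM, a limit of the assay rather than a number.
Compound 2, `CNc1ncc2c(-c3ccc(N4CCNCC4)nc3)nn(Cc3cn(Cc4ccccc4)nn3)c2n1`, in this assay: > 10000 nM, again only a limit.

For the measured compounds named here, compound 2 therefore stands at the limit of this assay, and the single measured step, a step that the two limits leave unreadable from compound 1 to compound 2, cannot be read because both ends sit at that limit, as the limit of > 10000 nM in this assay, at which 2 of the 2 values shown sit, records. Compound 3, `CNc1ncc2c(-c3ccc(N4CCNCC4)nc3)nn(Cc3cn(-c4ccsc4C(=O)OC)nn3)c2n1`, differs from compound 2 in one place: 2-(methoxycarbonyl)thiophen-3-yl in place of benzyl on an aromatic nitrogen. Going by the values given here, no measured step touches this change, since the only step available concerns a different group and is itself unreadable. Nothing shown supports a movement in either direction beyond the scatter, so the expectation rests on compound 2 staying where it is. Compound 3 is expected to give about 15000 nM in this assay, within roughly 3000 nM to 60000 nM. The step this estimate implies, a step that the limit leaves unreadable from compound 2 to compound 3, is expected to be none beyond the scatter, with a real chance that only a limit is reported again.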

Compound 3, half-maximal inhibitory concentration: > 10000 nM
Compound 3: a limit, no number; the forecaster's own chance of this, stated with the estimate: 70%; the middle value does not contradict the limit.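

For the compounds shown here, no step from compound 2 to compound 3 can be read, because both compounds stop at a limit of the assay rather than a number: the limit of > 10000 nM in this assay, at which 3 of the 3 values shown sit.

The compounds shown leave open how strongly each one actually inhibits in this assay, and whether these group changes shift that strength at all.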